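Ring hydroxyl methylation across two ester series

The compounds below may be only part of what the source reports. "The series", "measured", "known", "first", "only" and "open" are said of these compounds alone.

Measured so far in this assay:
compound 1 `O=C(/C=C/c1ccc(O)c(O)c1)OCc1c(-c2ccccc2)no[n+]1[O-]`: 2710 nM
compound 2 `COc1cc(/C=C/C(=O)OCc2c(-c3ccccc3)no[n+]2[O-])ccc1O`: 2060 nM
compound 3 `O=C(/C=C/c1ccc(OCCCCCCO[N+](=O)[O-])c(O)c1)OCCCCCCO[N+](=O)[O-]`: > 50000 nM

In a functional assay on A549 cells (Homo sapiens) for cytotoxicity, read by resazurin assay, with a stated time of 72 h (on this read-out lower numbers stand for stronger inhibition and higher numbers for weaker inhibition), compound 1 gives 2710 nM and compound 2 gives 2060 nM. The change between them, (methyl in place of hydrogen on an oxygen on an aromatic ring), gave a 1.3-fold lower number from compound 1 to compound 2 (0.12 log units; within the scatter). For compound 3 this assay reports only a limit, > 50000 nM, sitting at the limit of > 50000 nM in this assay, at which 1 of the 3 values shown sits. The difference between the core of compound 1 and the core of compound 3 is not broken down here.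

Compound 4 `COc1cc(/C=C/C(=O)OCCCCCCO[N+](=O)[O-])ccc1OCCCCCCO[N+](=O)[O-]` is not yet measured. It differs from compound 3 by methyl in place of hydrogen on an oxygen on an aromatic ring, the same change as from compound 1 to compound 2. Since that step was a 1.3-fold lower number from compound 1 to compound 2 (0.12 log units; within the scatter), a similarly small step is expected here. Compound 4 is therefore expected near 60000 nM, between 20000 nM and 200000 nM, most likely again reported as a limit. The step this estimate means is expected to be a step that the limit leaves unreadable from compound 3 to compound 4.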

Compound 4, half-maximal inhibitory concentration: > 50000 nM
Compound 4: no number, only a limit (the forecaster's own chance of this, stated with the estimate: 85%); the middle value lies beyond the limit too.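

In this assay compound 4 reads only as a limit, > 50000 nM. Compound 3 is likewise only a limit, > 50000 nM, and the step between these two compounds cannot be read. Still open, going by these compounds, is whether hydroxy to methoxy changes the value at all on the core of compound 3.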